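This account rests on a few compounds, and the source may have more. Where it says the series, first, only, none or still open, it means among the compounds named here.

In an in vivo ADME assay on the whole organism for pharmacokinetics, with Canis familiaris (Canis lupus familiaris) as the target, using cassette dosing, at a dose of 0.25 mg/kg by the intravenous route (a lower number here means slower removal, a higher number faster removal of the compound), compound 1 (`CCCS(=O)(=O)N1CCC(CNC(=O)c2ccc(Cl)cc2Cl)(C2CCCCC2O)CC1`) is reported only as a limit, > 15 mL/min/kg. Compound 2 (`CCCS(=O)(=O)N1CCC(CNC(=O)c2ccc(Cl)cc2Cl)(C2CCCCC2OC(C)=O)CC1`) is also reported only as a limit, > 15 mL/min/kg, so it has no exact number. Its position is the limit of > 15 mL/min/kg in this assay, at which 2 of the 2 values shown sit. Among the measured compounds shown here, the one measured step is a step that the two limits leave unreadable from compound 1 to compound 2, which gives no size to carry forward. Compound 3 (`CCCS(=O)(=O)N1CCC(CNC(=O)c2ccc(Cl)cc2Cl)(N2CCC2)CC1`) differs from compound 2 as follows: azetidin-1-yl in place of 2-acetoxycyclohexyl on a saturated ring carbon. With no readable step as a guide, no firm direction is expected, and the expected step is a step that the limit leaves unreadable from compound 2 to compound 3. For compound 3 the clearance is estimated at 18 mL/min/kg, within an expected range of 7 mL/min/kg to 40 mL/min/kg.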

Compound 3, clearance: > 15 mL/min/kg
Compound 3 gave a limit, no number (the forecaster's own chance of this, stated with the estimate: 55%); the middle value does not contradict the limit.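

Compound 3, like compound 1 and compound 2, is reported only as a limit in this assay, so no step among the three can be read: the limit of > 15 mL/min/kg in this assay, at which 3 of the 3 values shown sit.

The compounds shown leave open the actual clearance of each and whether any of these changes alters it.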